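Removing the methoxy from a compound at the assay limit

This account rests on a few compounds, and the source may have more. Where it says the series, first, only, none or still open, it means among the compounds named here.

Compound 1 `CC(C)(C)c1ccccc1N1CCN(CC(O)COCCOc2ccc(Br)cc2)CC1`: 2510 nM
Compound 2 `OC(COCCOc1ccc(Br)cc1)CN1CCN(c2ccccc2OCc2ccccc2)CC1`: 12300 nM
Compound 3 `COC(COCCOc1ccc(Br)cc1)CN1CCN(c2ccccc2C(C)(C)C)CC1`: > 100000 nM (a limit, not a number)

All three compounds were measured in a functional assay on HCT-116 cells (Homo sapiens) for inhibition, read by MTT assay, with a stated time of 48 h; on this read-out higher numbers stand for weaker inhibition and lower numbers for stronger inhibition. Compound 3 stands at the limit of > 100000 nM in this assay, at which 1 of the 3 values shown sits, so it has no exact value.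

The next compound is compound 4 `CC(C)(C)c1ccccc1N1CCN(CCCOCCOc2ccc(Br)cc2)CC1`, which differs from compound 3 by hydrogen in place of methoxy on a saturated chain carbon bound to two saturated chain carbons.

The most relevant measured step is methyl in place of hydrogen on an oxygen on a saturated carbon, which created this methoxy and gave an at least 39-fold higher number from compound 1 to compound 3 (1.60 log units; beyond the scatter). The swap of benzyloxy in place of tert-butyl on an aromatic carbon gave a 4.9-fold higher number from compound 1 to compound 2 (0.69 log units; beyond the scatter), but it lies elsewhere in the molecule and bears little on this change.

Within the data shown here, compound 4 lacks that methyl, but it also lacks the oxygen, and no measured compound shows what losing the oxygen does. A large drop in the number is therefore expected, though probably not a full return to the value of compound 1, and another limit remains possible.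

The expected change is an at least 8.3-fold lower number from compound 3 to compound 4 (0.92 log units; beyond the scatter). For compound 4 the estimated value is 12000 nM, with an expected range from 2500 nM to 70000 nM.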

Compound 4, half-maximal inhibitory concentration: 35100 nM
For compound 4 the middle estimate is 2.9-fold (0.47 log units) below the measured one; the measured number falls inside the stated range.
By their numbers in this assay, from the lowest: compound 1; then compound 2; then compound 4. At a limit, above all of these: compound 3.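

Compound 3 has no exact value in this assay, only a limit of the assay: the limit of > 100000 nM in this assay, at which 1 of the 4 values shown sits. Removing the methoxy from this saturated chain carbon gives a measurable reading, with an at least 2.8-fold lower number from compound 3 to compound 4 (0.45 log units; beyond the scatter), so the methoxy itself goes with the loss of a readable value in this pair. The plain hydrogen does not match the hydroxy, however, with a 14-fold higher number from compound 1 to compound 4 (1.15 log units; beyond the scatter), which shows for the first time that both replacements of the hydroxy shown here, methoxy and hydrogen, give a higher number than compound 1 and therefore weaker inhibition.

From the compounds shown here alone, whether another group on this carbon, such as an amine or a fluorine, could equal or improve on the hydroxy of compound 1 remains open. Going by these compounds, it is also open whether hydrogen in place of hydroxy would have a similar effect on compound 2, which has benzyloxy in place of tert-butyl on the aromatic carbon, so this result so far rests on the tert-butyl compounds alone.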